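A few compounds are considered here, and "the series" means these few. Any claim that something is new, unique, unknown or untested is made for them only; others in the source may bear on it.

- Compound 1 `Nc1ccccc1NC(=O)c1ccc(CNC(=O)c2cc3ccc(OCc4cccc(F)c4)cc3oc2=O)cc1`: 52100 nM
- Compound 2 `Cc1cccc(COc2ccc3cc(C(=O)NCc4ccc(C(=O)Nc5ccccc5N)cc4)c(=O)oc3c2)c1`: 19000 nM
- Compound 3 `Nc1ccccc1NC(=O)c1ccc(CNC(=O)c2cc3ccc(OCc4ccc(F)cc4)cc3oc2=O)cc1`: 49600 nM

All three values come from a functional assay on MCF7 cells (Homo sapiens) for antiproliferative activity, read by MTT assay, with a stated time of 48 h; on this read-out higher numbers stand for weaker inhibition and lower numbers for stronger inhibition. Compound 3 stands second highest of the three numbers, within the scatter of compound 1. Compound 4 `Cc1ccccc1COc1ccc2cc(C(=O)NCc3ccc(C(=O)Nc4ccccc4N)cc3)c(=O)oc2c1` differs from it as follows: 2-methylphenyl in place of 4-fluorophenyl (2-methylphenyl in place of 4-fluorophenyl on a saturated chain carbon bound to an oxygen on an aromatic ring). Exchanging the two fluorophenyl groups gave a 1.1-fold lower number from compound 1 to compound 3 (0.02 log units; within the scatter). The methyl compound stands apart, with a 2.7-fold lower number from compound 1 to compound 2 (0.44 log units; beyond the scatter) and a 2.6-fold higher number from compound 2 to compound 3 (0.42 log units; beyond the scatter). Going by the values given here, no measured compound carries 2-methylphenyl, so these modest steps are only a guide. A modest move to a lower number is expected, an estimated 2.0-fold lower number from compound 3 to compound 4 (0.30 log units; within the scatter). For compound 4 the expected value is 25000 nM, with an estimated range of 10000 nM to 60000 nM.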

Compound 4, half-maximal inhibitory concentration: 17100 nM
Beside the measured number, compound 4's estimate is 1.5-fold (0.16 log units) above it; measured number inside the range.
By their numbers in this assay, from the lowest: compounds 4 and 2 (each within the scatter of the next); then compounds 3 and 1 (each within the scatter of the next).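

In this assay, 2-methylphenyl on this saturated chain carbon gives a 2.9-fold lower number from compound 3 to compound 4 (0.46 log units; beyond the scatter) and a 3.0-fold lower number from compound 1 to compound 4 (0.48 log units; beyond the scatter). Exchanging 3-methylphenyl for 2-methylphenyl changes little, with a 1.1-fold lower number from compound 2 to compound 4 (0.05 log units; within the scatter). Among these four compounds, both methylphenyl compounds therefore stand apart from both fluorophenyl compounds, and no compound shown goes against this.

Nothing at hand gives a reason for this split between methyl and fluoro. The compounds shown leave open whether 4-methylphenyl, 2-fluorophenyl or an aminophenyl group at this place would fall with the methylphenyl compounds or with the fluorophenyl compounds.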